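Benzylic aryl swap on the shared thiazole-free core series

The compounds below may be only part of what the source reports. "The series", "measured", "known", "first", "only" and "open" are said of these compounds alone.

Within the data shown here, compound 2 `COc1cccc(Cc2nc(C)c(-c3ccc(C(N)=O)c(C)c3)s2)c1` stands lowest of the two numbers so far in a functional assay on cells for agonist activity at G-protein coupled receptor 52 (Homo sapiens), read by AlphaScreen and cAMP accumulation, with a stated time of 30 min (a higher number here means that more compound is needed for the effect, a lower number that less compound is needed), where it gives 160 nM. Compound 1 `Cc1cc(C(N)=O)ccc1-c1sc(Cc2cccc(C(F)(F)F)c2)nc1C` gives 1400 nM in this assay, a gap beyond the scatter. Compound 3 `Cc1cc(-c2sc(Cc3ccccc3Cl)nc2C)ccc1C(N)=O` is unmeasured; it carries 2-chlorophenyl in place of 3-methoxyphenyl on a saturated chain carbon bound to an aromatic carbon. Among the measured compounds shown here, no measured pair maps this exchange, so the expected step is uncertain, but a higher number is expected, of moderate size, since the one other aryl variant, compound 1, sits well above compound 2. Compound 3 is estimated at 500 nM, range 120 nM to 2000 nM. The expected step is a 3.1-fold higher number from compound 2 to compound 3 (0.49 log units; beyond the scatter).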

Compound 3, half-maximal effective concentration: 3900 nM
Compound 3: the middle estimate sits 7.8-fold (0.89 log units) below what was measured; the measured number lies above the stated range.
By their numbers in this assay, from the lowest: compound 2; then compound 1; then compound 3.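

In this assay, 2-chlorophenyl in place of 3-methoxyphenyl on a saturated chain carbon bound to an aromatic carbon gives a 24-fold higher number from compound 2 to compound 3 (1.39 log units; beyond the scatter), so the number at this position depends strongly on the aryl group. Compound 3 at 3900 nM also stands above compound 1 at 1400 nM and leaves compound 2 lowest of the three. Nothing available bears on the reason for this step.

Open, on these data alone, is whether the substituent or its ring position drives the gap. Unsubstituted phenyl, 3-chlorophenyl and 2-methoxyphenyl would separate these.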